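Cytotoxicity notes: from compound 3 to compound 4

This account rests on a few compounds, and the source may have more. Where it says the series, first, only, none or still open, it means among the compounds named here.

Measured in an ADME assay on MT4 cells (Homo sapiens) for cytotoxicity, read by MTT assay, with a stated time of 96 h; a lower number here means that less compound is tolerated, a higher number that more compound is tolerated:
- compound 1 `C/C(=N\NC(N)=O)c1ccc2c(c1)nc(-c1ccccn1)n2C1CCCCC1`: "not determined" (no result reported)
- compound 2 `COc1ccc(-c2nc3cc(/C(C)=N/NC(N)=S)ccc3n2C2CCCCC2)cc1`: 39000 nM
- compound 3 `COc1ccc(-c2nc3cc(/C(C)=N/NC(N)=S)ccc3n2C2CCCCC2)c(OC)c1`: 17000 nM

Compound 3, at 17000 nM, holds the lower of the two numbers available in this assay. Within the data shown here, the only other number belongs to compound 2, at 39000 nM, and compound 1 gives no result to compare.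

The next compound to read is compound 4 `C/C(=N\NC(N)=S)c1ccc2c(c1)nc(-c1ccccn1)n2C1CCCCC1`, with pyridin-2-yl in place of 2,4-dimethoxyphenyl on an aromatic carbon.

Among the measured compounds shown here, one measured step bears on this change, and only indirectly. Methoxy in place of hydrogen on an aromatic carbon gave a 2.3-fold lower number from compound 2 to compound 3 (0.36 log units; beyond the scatter), a modest step beyond the scatter. That methoxy sits within the group that now leaves, so losing the group is expected to move the number upward, towards compound 2 rather than away from it. For the measured compounds named here, no measured step shows a whole ring being exchanged, so the size remains uncertain and the range is wide.

The expected change is a 2.1-fold higher number from compound 3 to compound 4 (0.31 log units; beyond the scatter), a modest step to a higher number.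

For compound 4 the estimated value is 35000 nM, with an expected range of 13000 nM to 100000 nM.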

Compound 4, half-maximal cytotoxic concentration: 23000 nM
Beside the measured number, compound 4's estimate is 1.5-fold (0.18 log units) above it; the measured number falls inside the stated range.
By their numbers in this assay, from the lowest: compounds 3, 4 and 2 (each within the scatter of the next, the first and the last beyond it).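

In this assay, at the aromatic carbon between two ring nitrogen atoms, pyridin-2-yl in place of 2,4-dimethoxyphenyl gives a 1.4-fold higher number from compound 3 to compound 4 (0.13 log units; within the scatter), and pyridin-2-yl in place of 4-methoxyphenyl gives a 1.7-fold lower number from compound 2 to compound 4 (0.23 log units; within the scatter). Among these compounds, this is the first exchange of the whole ring at this place, and neither step separates compound 4 from its neighbour, although the ring that enters has one hetero atom and fewer heavy atoms, and the earlier methoxy change alone gave a 2.3-fold lower number from compound 2 to compound 3 (0.36 log units; beyond the scatter). At this place, then, a ring with no methoxy group stands within the scatter of both methoxy-bearing rings, and no measurement at hand accounts for this.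

Open, on these data alone, is whether this place accepts something other than a six-membered aromatic ring, such as an amine or a carboxylic acid, and whether the cyclohexyl group can give way to a longer chain. The exchange of carbonyl for thiocarbonyl cannot be read, as compound 1 gives "not determined" (no result reported).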